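Methyl on the ring nitrogen: compound 2 to compound 4

The compounds below may be only part of what the source reports. "The series", "measured", "known", "first", "only" and "open" are said of these compounds alone.

Measured in an assay on isolated protein for inhibition of MAP kinase-activated protein kinase 5 (Homo sapiens), read by mobility shift assay, tested at 30 uM; a higher number here means more inhibition at the concentration tested (going by the name of the read-out), a lower number less inhibition:
compound 2 `COc1ccc(-c2cc3[nH]nc(N)c3c(=O)[nH]2)cc1`: 7%
compound 3 `CN1CCN(c2ccc(-c3cc4[nH]nc(N)c4c(=O)[nH]3)cc2)CC1`: 11%
compound 1 `Nc1n[nH]c2cc(-c3cccnc3)[nH]c(=O)c12`: 12%

In this assay compound 2 sits at the low end of the three numbers, but its gaps to compound 3 and to compound 1 are both within the scatter, so the three compounds cannot be told apart. Among the compounds with values here, the only step between measured compounds is a number 4 percentage points higher from compound 2 to compound 3 (within the scatter); it swaps a substituent on the aromatic carbon and leaves the shared core untouched, so it says nothing about the ring nitrogen. Compound 4 `COc1ccc(-c2cc3c(c(N)nn3C)c(=O)[nH]2)cc1` differs from compound 2 by methyl in place of hydrogen on an aromatic nitrogen. Within the data shown here, no measured step touches that nitrogen, and with all three numbers low, compound 4 is expected to show a number 1 percentage points lower from compound 2 to compound 4 (within the scatter), nothing beyond the scatter. The estimate for compound 4 is 6%, in the range 0% to 18%.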

Compound 4, a percentage reported as inhibition, at one concentration (the size of the read-out at that concentration, not a potency): 16%
Compound 4: the middle estimate sits 10 percentage points below what was measured, and the stated range covers the measured number.
By their numbers in this assay, from the lowest: compounds 2, 3, 1 and 4 (each within the scatter of the next).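

Methyl in place of hydrogen on the aromatic nitrogen, the only step read at this position, gives a number 9 percentage points higher from compound 2 to compound 4 (within the scatter) in this assay. Replacing this hydrogen therefore produces no change beyond the scatter, although the low number of compound 2 leaves little room to detect a loss. No measured information bears on this result.

Still open, from the compounds shown here alone, is whether a longer chain or an aminoethyl group on this nitrogen would move the number beyond the scatter. Going by these compounds, it is also open whether any group here gives substantial inhibition.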